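The compounds below may be only part of what the source reports. "The series", "measured", "known", "first", "only" and "open" are said of these compounds alone.

Measured in an ADME assay on HepG2 cells (Homo sapiens) for cytotoxicity, read by MTT assay, with a stated time of 72 h; a higher number here means that more compound is tolerated, a lower number that less compound is tolerated:
- Compound 1 `O=[N+]([O-])c1c(CS(=O)(=O)c2ccccc2)nc2c(C#Cc3cccs3)cc(Cl)cn12`: > 3900 nM, a limit
- Compound 2 `O=[N+]([O-])c1c(CS(=O)(=O)c2ccccc2)nc2c(C#CCCO)cc(Cl)cn12`: > 125000 nM, a limit

For the measured compounds named here, compound 2 has no exact number in this assay, only a limit, and the one other value is a limit too. Compound 3 `CC(C)(O)C#Cc1cc(Cl)cn2c([N+](=O)[O-])c(CS(=O)(=O)c3ccccc3)nc12` differs from it as follows: 1-hydroxy-1-methylethyl in place of 2-hydroxyethyl on a triple-bonded carbon. In words, 1-hydroxy-1-methylethyl stands in place of 2-hydroxyethyl on a triple-bonded carbon.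

Going by the values given here, the only measured step that bears on this is a step that the two limits leave unreadable from compound 1 to compound 2. It gives no size to carry over, and it replaces thiophen-2-yl, a group absent from compound 3. No step beyond the scatter is therefore expected in this assay, and no direction is favoured. The expected step is a number no higher from compound 2 to compound 3 (the limit leaves the size open). That expectation starts from compound 2 at > 125000 nM, which is a limit. Compound 3 is estimated at 125000 nM, with an expected range of 40000 nM to 250000 nM.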

Compound 3, half-maximal cytotoxic concentration: > 62500 nM
Compound 3: no number, only a limit; the forecaster's own chance of this, stated with the estimate: 65%; the middle value is on the limit's open side.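

In this assay compound 3 gives > 62500 nM, a limit. For the compounds shown here, compound 1 and compound 2 are also known only as limits, so no step among the three can be read. The compounds shown leave open whether 1-hydroxy-1-methylethyl, 2-hydroxyethyl and thiophen-2-yl differ at all in this read-out.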